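A Second Fluoro Group on the Phenyl Ring of Compound 2

The source may report more compounds than this note shows. Statements on the series, on what has been measured and on what is new or still open speak of the compounds shown alone.

Within the data shown here, compound 2 `O=C(Nc1nc(-c2cccc(F)c2)cs1)c1cc([N+](=O)[O-])ccc1Cl` is one of three compounds measured in an ADME assay for permeability, using PAMPA, at pH 7.4; a lower number here means that the compound crosses the layer more slowly, a higher number that the compound crosses the layer faster. In this assay compound 2 gives 3 10^-6 cm/s, level at the digits shown with compound 1 `O=C(Nc1nc(-c2ccc(Cl)cc2)cs1)c1cc([N+](=O)[O-])ccc1Cl`, which gives 3 10^-6 cm/s; together these two are the lowest of the three numbers. The furthest from compound 2 is compound 3 `O=C(Nc1nc2ccc(F)cc2s1)c1cc([N+](=O)[O-])ccc1Cl`, which gives 10 10^-6 cm/s, a gap beyond the scatter. Compound 4 `O=C(Nc1nc(-c2ccc(F)c(F)c2)cs1)c1cc([N+](=O)[O-])ccc1Cl` has not yet been measured. It differs from compound 2 by fluoro in place of hydrogen on an aromatic carbon. Among the measured compounds shown here, the only measured step between compounds differing at a single place is no change at the digits printed from compound 1 to compound 2 (within the scatter), in which a change of the halogen and its position on the same phenyl ring left the number unchanged within the scatter. For the measured compounds named here, no measured step adds a fluoro group to a ring that already carries one, so that single step is all that bears on the question, and it points to a change of no size beyond the scatter. Compound 4 is therefore expected to show a 1.2-fold higher number from compound 2 to compound 4 (0.07 log units; within the scatter). The estimate for compound 4 is 3.5 10^-6 cm/s, with a range from 1.8 10^-6 cm/s to 7 10^-6 cm/s.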

Compound 4, apparent permeability: 37 10^-6 cm/s
Beside the measured number, compound 4's estimate is 11-fold (1.02 log units) below it; measured number outside the range, above it.
By their numbers in this assay, from the lowest: compounds 1 and 2 (each within the scatter of the next); then compound 3; then compound 4.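

In this assay, among these compounds, this position on the phenyl ring proves far more responsive than the earlier compounds suggested: fluoro in place of hydrogen, ortho to a fluoro group and para to a large group, gives a 12-fold higher number from compound 2 to compound 4 (1.09 log units; beyond the scatter), whereas the only earlier step between compounds differing in one place was no change at the digits printed from compound 1 to compound 2 (within the scatter). Replacing 4-chlorophenyl with 3,4-difluorophenyl gives much the same result, a 12-fold higher number from compound 1 to compound 4 (1.09 log units; beyond the scatter), so the large rise appears in both steps that lead to the 3,4-difluorophenyl group. Nothing available explains the size of this rise.

The compounds shown leave open whether fluoro at this position would give such a rise without the existing fluoro group. They also leave open whether a different group here, such as methoxy, nitrile or an amine, would do the same.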